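Nitro in Place of Trifluoromethyl in Compound 4

The compounds below may be only part of what the source reports. "The series", "measured", "known", "first", "only" and "open" are said of these compounds alone.

Compound 3 `O=C(Nc1cc(-c2ccccc2)nn1-c1ccccc1)c1ccc(C(F)(F)F)cc1` gives the lowest of the three numbers in an assay on HEK293 cells for displacement of a labelled ligand from metabotropic glutamate receptor 5 (Rattus norvegicus) (on this read-out higher numbers stand for weaker inhibition and lower numbers for stronger inhibition), at 990 nM. Compound 2 `COc1cccc(C(=O)Nc2cc(-c3ccccc3)nn2-c2ccccc2)c1` gives 1290 nM, a gap within the scatter, while compound 1 `O=C(Nc1cc(-c2ccccc2)nn1-c1ccccc1)c1ccccc1` gives 4180 nM, so that a 4.2-fold lower number from compound 1 to compound 3 (0.63 log units; beyond the scatter). Compound 4 `O=C(Nc1cc(-c2ccccc2)nn1-c1ccccc1)c1ccc([N+](=O)[O-])cc1` differs from compound 3 by nitro in place of trifluoromethyl on an aromatic carbon. For the measured compounds named here, no measured step swaps one such group for another; the steps that bear on it are a 4.2-fold lower number from compound 1 to compound 3 (0.63 log units; beyond the scatter) and a 3.2-fold lower number from compound 1 to compound 2 (0.51 log units; beyond the scatter), both additions to the unsubstituted compound 1, and the exchange of one group for another in a 1.3-fold lower number from compound 2 to compound 3 (0.11 log units; within the scatter). A further exchange of this kind is therefore expected to stay within the scatter, and compound 4 is estimated at 1100 nM, within 450 nM to 2700 nM, a step of a 1.1-fold higher number from compound 3 to compound 4 (0.05 log units; within the scatter).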

Compound 4, inhibition constant: 250 nM
Beside the measured number, compound 4's estimate is 4.4-fold (0.64 log units) above it; measured number outside the range, below it.
By their numbers in this assay, from the lowest: compound 4; then compounds 3 and 2 (each within the scatter of the next); then compound 1.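

In this assay the choice of group at this position proves to matter, with a 4.0-fold lower number from compound 3 to compound 4 (0.60 log units; beyond the scatter) showing that one exchange can reach beyond the scatter, which the earlier exchange did not. The 4-nitrophenyl group also separates from 3-methoxyphenyl in a 5.2-fold lower number from compound 2 to compound 4 (0.71 log units; beyond the scatter) and nitro gives a 17-fold lower number from compound 1 to compound 4 (1.22 log units; beyond the scatter) as the only large step among these compounds. No evidence at hand says what lies behind the gain with nitro. As far as these compounds go, whether a nitrile, an amine or a carboxylic acid in the same place would match nitro remains open, as does whether nitro would give the same step elsewhere on this ring.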